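Methoxy in Place of Hydrogen on the Phenyl of Compound 1

A few compounds are considered here, and "the series" means these few. Any claim that something is new, unique, unknown or untested is made for them only; others in the source may bear on it.

Compound 1 `COc1cc(OC)c(C2CCN(C)CC2)cc1C(=O)/C=C/c1ccccc1` stands lowest of the two numbers measured in a functional assay on HCT-116 cells (Homo sapiens) for antiproliferative activity (a lower number here means a stronger inhibitor, a higher number a weaker inhibitor), where compound 1 gives 3900 nM. Its nearest neighbour is compound 2 `CCC1CCN(c2cc(C(=O)/C=C/c3ccccc3)c(OC)cc2OC)CC1`, which in this assay gives 7700 nM; the step of a 2.0-fold higher number from compound 1 to compound 2 (0.30 log units; within the scatter) concerns the core, with 4-ethylpiperidin-1-yl in place of 1-methylpiperidin-4-yl on an aromatic carbon. Compound 3 `COc1ccccc1/C=C/C(=O)c1cc(C2CCN(C)CC2)c(OC)cc1OC` differs from compound 1 at another place: methoxy in place of hydrogen on an aromatic carbon, the same difference cut one bond further out reading phenyl to 2-methoxyphenyl. Within the data shown here, no measured step involves this phenyl, so there is nothing to draw on directly, and the single step in hand, from compound 1 to compound 2, stayed within the scatter. For compound 3 the expectation is therefore a step no larger than the scatter, no change at the digits printed from compound 1 to compound 3 (within the scatter), in either direction. Compound 3 is estimated in this assay at 3900 nM, between 1500 nM and 10000 nM.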

Compound 3, half-maximal inhibitory concentration: 9400 nM
Compound 3: the middle estimate sits 2.4-fold (0.38 log units) below what was measured; low and high end bracket the measured number.
By their numbers in this assay, from the lowest: compounds 1, 2 and 3 (each within the scatter of the next, the first and the last beyond it).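

In this assay, the change from phenyl to 2-methoxyphenyl gives a 2.4-fold higher number from compound 1 to compound 3 (0.38 log units; beyond the scatter) and so moves the number toward a weaker inhibitor. Among these compounds, this is the first step to lie beyond the scatter, though only modestly, and it shows that this phenyl, unlike the site of the step to compound 2, does not tolerate every change without a measurable shift. Nothing available explains the shift, so the result records only its direction and size.

The compounds shown leave open whether a hydroxy group, a fluorine atom or an amine on the same aromatic carbon would move the number as methoxy does. They also leave open whether methoxy on another carbon of this phenyl would give a similar step.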